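The source may hold more compounds than are shown below. What is called first, only, known or untested is meant among the compounds shown, and "the series" means these compounds.

Measured in a physicochemical assay for solubility, at pH 6; a lower number here means a less soluble compound, a higher number a more soluble compound:
compound 1 `NC(=O)c1ccc(-c2cc(-c3ccc([N+](=O)[O-])cc3)nc(-c3ccco3)c2)cc1` gives 8000 nM
compound 2 `N#Cc1ccc(-c2cc(-c3ccc(C(N)=O)cc3)cc(-c3ccco3)n2)cc1` gives 10000 nM
compound 3 `Cn1ccnc1-c1cc(-c2ccc(C(N)=O)cc2)cc(-c2ccc(C#N)cc2)n1` gives 8000 nM

Compound 2 sits alongside compound 1 and compound 3: the step of a 1.3-fold higher number from compound 1 to compound 2 (0.10 log units; within the scatter) and the step of a 1.3-fold lower number from compound 2 to compound 3 (0.10 log units; within the scatter) both stay within the scatter, so the three numbers cannot be ranked. Compound 4 `NC(=O)c1ccc(-c2cc(-c3ccc(-c4cnco4)cc3)nc(-c3ccco3)c2)cc1` is not yet measured; it differs from compound 2 in one place: 1,3-oxazol-5-yl in place of cyano on an aromatic carbon. For the measured compounds named here, no measured step replaces the cyano with an aromatic group. The nearest comparison is the exchange at the same carbon from compound 1 to compound 2, which stayed within the scatter, as did the exchange from compound 2 to compound 3. For compound 4 the step of a 1.1-fold lower number from compound 2 to compound 4 (0.05 log units; within the scatter) is therefore expected to stay within the scatter, with no direction called. Compound 4 is estimated at 9000 nM in this assay, range 3500 nM to 23000 nM.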

Compound 4, solubility: 15000 nM
Compound 4: the middle estimate sits 1.7-fold (0.22 log units) below what was measured; the range from low to high includes it.
By their numbers in this assay, from the lowest: compounds 1, 3, 2 and 4 (each within the scatter of the next).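

In this assay, the aromatic carbon para to a large group now carries a whole 1,3-oxazol-5-yl ring rather than only a cyano or nitro group, and both new steps stay within the scatter: a 1.5-fold higher number from compound 2 to compound 4 (0.18 log units; within the scatter), and a 1.9-fold higher number from compound 1 to compound 4 (0.27 log units; within the scatter). All three groups at this carbon therefore give numbers that cannot be ranked. Nothing available bears on a cause for these numbers.

On these data alone, whether an amine or a carboxylic acid at this carbon would give a step beyond the scatter remains open. Also open, as far as these compounds go, is whether the 1,3-oxazol-5-yl group gives the same reading with 1-methyl-1H-imidazol-2-yl in place of furan-2-yl.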